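Two methoxy steps in a growth-inhibition series

The source may report more compounds than this note shows. Statements on the series, on what has been measured and on what is new or still open speak of the compounds shown alone.

Measured in a functional assay on HepG2 cells (Homo sapiens) for inhibition, read by MTT assay, with a stated time of 24 h; a lower number here means a stronger inhibitor of growth, a higher number a weaker inhibitor of growth:
- compound 1 `Cn1cc(-c2nc3ccccc3n2C(=O)c2ccccc2)c2ccccc21` gives 42300 nM
- compound 2 `COc1ccccc1C(=O)n1c(-c2cn(C)c3ccccc23)nc2ccccc21` gives 31800 nM
- compound 3 `COc1ccc2c(c1)c(-c1nc3ccccc3n1C(=O)c1ccccc1)cn2C` gives 37900 nM

Not yet measured: compound 4 `COc1ccc2c(c1)c(-c1nc3ccccc3n1C(=O)c1ccccc1OC)cn2C`

Compound 3 at 37900 nM lies within the scatter of both compound 1 and compound 2, so the three values form a single group with no meaningful order.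

The move to compound 4 is methoxy in place of hydrogen on an aromatic carbon and consists of methoxy in place of hydrogen on an aromatic carbon, ortho to a large group, or phenyl to 2-methoxyphenyl. The same replacement has been measured once, without the second methoxy group, as a 1.3-fold lower number from compound 1 to compound 2 (0.12 log units; within the scatter) in this assay. The other methoxy replacement, kept in compound 4, was measured as a 1.1-fold lower number from compound 1 to compound 3 (0.05 log units; within the scatter) and is equally small. Going by the values given here, no measured compound yet carries both methoxy groups, so simple addition of the two steps is an untested assumption. Neither step gives grounds for expecting a clear shift. The estimated step is a 1.3-fold lower number from compound 3 to compound 4 (0.10 log units; within the scatter) and nothing beyond the scatter is expected. For compound 4 the expected value is 30000 nM with an estimated range from 18000 nM to 47000 nM.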

Compound 4, concentration for 50% growth inhibition: 23600 nM
Estimate against measurement, compound 4: 1.3-fold (0.10 log units) above, within the range that was stated.
By their numbers in this assay, from the lowest: compounds 4, 2, 3 and 1 (each within the scatter of the next).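

Phenyl to 2-methoxyphenyl, with the methoxy ortho to a large group, can now be read on a second core in this assay as a 1.6-fold lower number from compound 3 to compound 4 (0.21 log units; within the scatter), and its size does not depend on the core beyond what repeated measurement would allow: the same change on two cores in this assay, a 1.3-fold lower number (0.12 log units; within the scatter) from compound 1 to compound 2 and a 1.6-fold lower number (0.21 log units; within the scatter) from compound 3 to compound 4, 1.2-fold (0.08 log units) apart, within the scatter of two such steps. The other methoxy replacement, read with the 2-methoxyphenyl already in place, gives a 1.3-fold lower number from compound 2 to compound 4 (0.13 log units; within the scatter), and it too agrees with its earlier reading: the same change on two cores in this assay, a 1.1-fold lower number (0.05 log units; within the scatter) from compound 1 to compound 3 and a 1.3-fold lower number (0.13 log units; within the scatter) from compound 2 to compound 4, 1.2-fold (0.08 log units) apart, within the scatter of two such steps. Going by these compounds alone, compound 4 is the only compound carrying both methoxy groups, and it shows no departure from simple addition of the two steps, although every step in this set lies within the scatter and the four compounds therefore have no meaningful order.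

Whether this position can move the number beyond the scatter remains open, as only hydrogen and methoxy are shown there, and an amine, a carboxylic acid or a longer alkoxy chain in place of the methoxy would test it. On these data alone, whether the two methoxy steps hold beyond these two cores and this one cell assay also remains open.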